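Dropping One Chloro from a Weak Aryl Enone Acid

This account rests on a few compounds, and the source may have more. Where it says the series, first, only, none or still open, it means among the compounds named here.

Compound 1, `O=C(O)/C=C/C(=O)c1ccc(Cl)cc1Cl`: 58500 nM in a functional assay on K562 cells (Homo sapiens) for inhibition, read by MTT assay, with a stated time of 72 h; a higher number here means a weaker inhibitor, a lower number a stronger inhibitor.
Compound 2, `Cc1cc(C2CCCCC2)c(C)cc1C(=O)/C=C/C(=O)O`: 4240 nM in this assay.

Compound 1 has the higher of the two numbers and so is the weaker inhibitor; compound 2 lies beyond the scatter below it. Compound 3, `O=C(O)/C=C/C(=O)c1ccc(Cl)cc1`, is not yet measured. It differs from compound 1 by hydrogen in place of chloro on an aromatic carbon. Going by the values given here, no measured pair shows this change directly. Because compound 2, carrying several groups, reaches 4240 nM while compound 1 sits at 58500 nM, removing a group from compound 1 is expected to give a small shift toward weaker inhibition, a 1.4-fold higher number from compound 1 to compound 3 (0.14 log units; within the scatter), possibly within the scatter. Compound 3 is expected near 80000 nM, between 25000 nM and 250000 nM.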

Compound 3, half-maximal inhibitory concentration: 21700 nM
Beside the measured number, compound 3's estimate is 3.7-fold (0.57 log units) above it, outside the stated range (below it).
By their numbers in this assay, from the lowest: compound 2; then compound 3; then compound 1.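

Replacing the chloro that sits ortho to a group of 7 heavy atoms with hydrogen gives a 2.7-fold lower number from compound 1 to compound 3 (0.43 log units; beyond the scatter) in this assay. This chloro is therefore not needed for inhibition, and compound 1 is a modestly weaker inhibitor with it than compound 3 is without it. No measurement available here explains this gain in strength. Still open, from the compounds shown here alone, is how a methyl or methoxy group at this position would compare with hydrogen. Going by these compounds, the effect of removing the remaining chloro is also open.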